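The source may report more compounds than this note shows. Statements on the series, on what has been measured and on what is new or still open speak of the compounds shown alone.

Measured compounds:
- compound 1, `C[Se]c1nc(N)c2ccccc2n1` — 23600 nM
- compound 2, `C[Se]c1nc(N)c2cccnc2n1` — 39700 nM
- compound 3, `CSc1ccc(CNc2nc([Se]C)nc3ccccc23)cc1` — 35900 nM

All three numbers come from an ADME assay on BEAS-2B cells (Homo sapiens) for cytotoxicity, read by MTT assay, with a stated time of 72 h; a lower number here means a stronger inhibitor of growth, a higher number a weaker inhibitor of growth. In this assay compound 1 gives 23600 nM, the lowest of the three numbers, yet its separation from compound 3 and from compound 2 falls within the scatter of repeat measurements, so no ordering among the three can be claimed. Compound 2 gives 39700 nM and compound 3 gives 35900 nM; across the series the readings sit in one narrow band.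

The next compound in the series is compound 4, `Nc1nc([SeH])nc2ccccc12`, which has not yet been run in this assay. Relative to compound 1 it carries a single change: hydrogen in place of methyl on a selenium. Within the data shown here, no pair of measured compounds that differ only in this way has been run, so there is no measured step to lean on. Given that the three measured compounds, with their varied substitution, all land within the scatter of each other, the expectation for the step from compound 1 to compound 4 is one of no change beyond the scatter, in either direction, expressed as a 1.3-fold higher number from compound 1 to compound 4 (0.10 log units; within the scatter). Compound 4 is therefore estimated at 30000 nM, with a range from 10000 nM to 90000 nM.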

Compound 4, concentration for 50% growth inhibition: 80 nM
Compound 4: the middle estimate sits 380-fold (2.57 log units) above what was measured; the measured number lies below the stated range.
By their numbers in this assay, from the lowest: compound 4; then compounds 1, 3 and 2 (each within the scatter of the next).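

In this assay, hydrogen in place of methyl on a selenium whose other neighbour is an aromatic carbon gives a 300-fold lower number from compound 1 to compound 4 (2.47 log units; beyond the scatter), so this position is highly sensitive to this single change. Among these compounds, compounds 1, 2 and 3 all keep the methyl on selenium and lie within the scatter of one another, so they gave no sign of this sensitivity; the step from methyl to hydrogen is the only single change so far read beyond the scatter. Nothing available accounts for the size of this step, and the change itself is the only observation in hand.

From the compounds shown here alone, a single pair carries this finding, so it remains open whether hydrogen on selenium has a similar effect on the cores of compound 2 and compound 3. Going by these compounds, it is also open how the number responds to other groups on the selenium, such as ethyl, a longer chain or benzyl, and so whether the step belongs to hydrogen specifically or to the loss of methyl.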